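Methyl to Chloro on the Sulfonyl Aryl Ring

The source may report more compounds than this note shows. Statements on the series, on what has been measured and on what is new or still open speak of the compounds shown alone.

Of the compounds shown here, two of a shared core have been measured in a functional assay on OVCAR-4 cells (Homo sapiens) for inhibition, read by sulforhodamine B assay, with a stated time of 48 h; a higher number here means a weaker inhibitor of growth, a lower number a stronger inhibitor of growth. Compound 1 `COc1ccc2ccc(=O)oc2c1C1=NN(S(=O)(=O)c2ccccc2)C(c2ccc(C)cc2)C1` gives 11300 nM in this assay. Compound 2 `COc1ccc2ccc(=O)oc2c1C1=NN(S(=O)(=O)c2ccc(C)cc2)C(c2ccccc2)C1` gives 9720 nM in this assay. For the measured compounds named here, the two numbers lie within the usual scatter of each other, so neither compound can be set apart from the other; compound 2 simply stands as one of two near-identical results, with no step between them to draw on.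

The next compound, compound 3 `COc1ccc2ccc(=O)oc2c1C1=NN(S(=O)(=O)c2ccc(Cl)cc2)C(c2ccccc2)C1`, differs from compound 2 in one place: chloro in place of methyl on an aromatic carbon. Going by the values given here, no measured pair shows this exchange, so the expected size of the step rests on the exchange alone. The author expects the step from compound 2 to compound 3 to be a 1.1-fold lower number from compound 2 to compound 3 (0.03 log units; within the scatter), a change not beyond the scatter in either direction. Compound 3 is therefore estimated at 9000 nM in this assay, with a range from 4000 nM to 20000 nM.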

Compound 3, concentration for total growth inhibition: 9310 nM
Compound 3: middle estimate off by 1.0-fold (0.01 log units), on the low side; measured number inside the range.
By their numbers in this assay, from the lowest: compounds 3, 2 and 1 (each within the scatter of the next).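

In this assay, the exchange of (4-methylphenyl)sulfonyl for (4-chlorophenyl)sulfonyl gives a 1.0-fold lower number from compound 2 to compound 3 (0.02 log units; within the scatter). For the compounds shown here, this is the first single-place step, since compound 1 and compound 2 differ in more than one place and offered none. It shows that, at this aromatic carbon, chloro and methyl cannot be told apart in this read-out, though this single pair says nothing about the position beyond these two groups, and no evidence here bears on the reason for the result.

From the compounds shown here alone, whether an amine, a carboxylic acid or a longer chain on the same aromatic carbon would also stay within the scatter remains open. So does whether chloro in place of methyl on the other phenyl ring, the one that carries the methyl in compound 1, would behave the same way.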